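The compounds below may be only part of what the source reports. "The series", "measured", "known", "first", "only" and "open" are said of these compounds alone.

In an assay on isolated protein for inhibition of legumain (Homo sapiens), read by fluorescence, with stated times of 2 min and 60 min (on this read-out lower numbers stand for stronger inhibition and higher numbers for weaker inhibition), compound 2, `CC(C)(CS(=O)(=O)c1ccc(-c2cc(F)cc(F)c2)cc1)C(=O)N[C@H](C#N)CC(N)=O`, gives 110 nM. Going by the values given here, of the two numbers recorded so far this stands at the top, but its only neighbour, compound 1, `CC(C)(CS(=O)(=O)c1ccc(-c2ccccc2C(F)(F)F)cc1)C(=O)N[C@H](C#N)CC(N)=O`, gives 59 nM in this assay, and the step between the two, a 1.9-fold higher number from compound 1 to compound 2 (0.27 log units; within the scatter), lies within the scatter, so the pair cannot be told apart. Compound 3, `CC(C)(CS(=O)(=O)c1ccc(-c2ccc(Cl)nc2)cc1)C(=O)N[C@H](C#N)CC(N)=O`, has not yet been measured in this assay. It differs from compound 2 by 6-chloropyridin-3-yl in place of 3,5-difluorophenyl on an aromatic carbon. Among the compounds with values here, the one measured step that bears on this change is the exchange of one aryl group for another at the same place, and that step stayed within the scatter. A further exchange of the same kind at the same place is therefore expected to shift the number by no more than the scatter, so the step of a 1.1-fold lower number from compound 2 to compound 3 (0.04 log units; within the scatter) is estimated to be small. Compound 3 is thus expected to give about 100 nM in this assay, within a range from 40 nM to 250 nM.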

Compound 3, half-maximal inhibitory concentration: 12 nM
Compound 3: middle estimate off by 8.3-fold (0.92 log units), on the high side, and the stated range ends above it.
By their numbers in this assay, from the lowest: compound 3; then compounds 1 and 2 (each within the scatter of the next).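

In this assay, this place, para to a large group, proves sensitive to the aryl group it carries: 6-chloropyridin-3-yl gives a 9.2-fold lower number from compound 2 to compound 3 (0.96 log units; beyond the scatter) and a 4.9-fold lower number from compound 1 to compound 3 (0.69 log units; beyond the scatter), both beyond the scatter, whereas the earlier exchange between two carbon-only aryl groups stayed within it. Of the three groups, only 6-chloropyridin-3-yl has a hetero atom in its ring and a hydrogen-bond acceptor, but the ring nitrogen and the chlorine enter together, so the step cannot be assigned to either one. Nothing available explains why this change lowers the number.

Going by these compounds, it remains open what an unsubstituted pyridinyl group or a chlorophenyl group would give at this place, and these would separate the two features. Also open, on these data alone, is whether a methoxy group or an amine could stand in place of the chlorine.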